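Compound 2 to compound 4: repositioned acid on the aryl ether

The source may hold more compounds than are shown below. What is called first, only, known or untested is meant among the compounds shown, and "the series" means these compounds.

Working notes on the series sharing the core of compound 1 `CCC(=O)c1ccc(OCCCCOc2ccc(F)c(C(=O)O)c2)c(C)c1O`, for which the result in an assay on HEK293 cells for positive allosteric modulation of metabotropic glutamate receptor 3 (Rattus norvegicus), read by thallium flux, with a stated time of 2.5 min (on this read-out lower numbers stand for an effect already at smaller amounts and higher numbers for an effect only at larger amounts of compound), is "not determined" (no result reported). Within the data shown here, compound 2 `Cc1c(OCCCCOc2ccc(F)c(C(=O)O)c2)ccc(C(=O)CC2CCCC2)c1O` gives 2490 nM in this assay and stands highest of the two numbers so far. Among the measured compounds shown here, compound 3 `Cc1c(OCCCCOc2ccc(F)c(C(=O)O)c2)ccc(C(=O)CC(C)(C)C)c1O` gives 258 nM in this assay, and the single measured step, a 9.7-fold lower number from compound 2 to compound 3 (0.98 log units; beyond the scatter), concerns only the group on the saturated chain carbon bound to the carbonyl carbon.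

Compound 4 `Cc1c(OCCCCOc2ccc(C(=O)O)c(Cl)c2)ccc(C(=O)CC2CCCC2)c1O` keeps that chain unchanged and instead alters the aryl end of the ether linker: 4-carboxy-3-chlorophenyl in place of 3-carboxy-4-fluorophenyl on an oxygen on a saturated carbon. For the measured compounds named here, no measured step touches this part of the molecule; the step from compound 2 to compound 3 lies elsewhere and gives no guidance on moving the carboxylic acid and exchanging fluorine for chlorine. As far as these compounds go, with nothing to anchor a direction, the expectation for this assay is a step of a 1.0-fold higher number from compound 2 to compound 4 (0.00 log units; within the scatter), that is, no change beyond the scatter, but with a wide band to reflect that the change is untested.

Compound 4 is therefore estimated at 2500 nM in this assay, within 700 nM to 9000 nM.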

Compound 4, half-maximal effective concentration: 2250 nM
The estimate for compound 4 lay 1.1-fold (0.05 log units) above the measured number; low and high end bracket the measured number.
By their numbers in this assay, from the lowest: compound 3; then compounds 4 and 2 (each within the scatter of the next).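

In this assay, the aryl end of the ether linker now has a measured step of its own: a 1.1-fold lower number from compound 2 to compound 4 (0.04 log units; within the scatter) with the cyclopentyl chain held fixed. Moving the carboxylic acid and exchanging fluorine for chlorine in one change, 4-carboxy-3-chlorophenyl in place of 3-carboxy-4-fluorophenyl, therefore leaves the number within the scatter in this series, whereas the only other measured step, a 9.7-fold lower number from compound 2 to compound 3 (0.98 log units; beyond the scatter) at the chain group, lies beyond it. No available evidence bears on why this change leaves the number within the scatter.

As far as these compounds go, the step combines two alterations, so it remains open whether each alone would also stay within the scatter or whether their separate effects offset each other, and whether the same result would hold with tert-butyl in place of cyclopentyl on the chain. Also open, from the compounds shown here alone, is how this aryl end would respond if the carboxylic acid gave way to a tetrazole or a primary amide, or if chlorine gave way to a methyl group or bromine.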